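The compounds below may be only part of what the source reports. "The series", "measured", "known", "first", "only" and "open" are said of these compounds alone.

Measured compounds in an assay on SH-EP1 cells for displacement of a labelled ligand from Neuronal acetylcholine receptor; alpha4/beta2 (Homo sapiens), read by scintillation counting; on this read-out lower numbers stand for stronger inhibition and higher numbers for weaker inhibition:
compound 1 `O=C(C1CC1)N1CC2CC1CN2` gives 2800 nM
compound 2 `O=C(C1CCC1)N1CC2CC(C1)N2` gives 16 nM
compound 3 `O=C(CC1C=CCC1)N1CC2CC(C1)N2` gives 53 nM

Compound 2 holds the lowest number of the three in this assay; compound 3 sits nearest to it, and the step between them lies beyond the scatter, while compound 1, built on a differently joined core, lies far above both.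

Compound 4 `C[C@@H]1C[C@@H]1C(=O)N1CC2CC(C1)N2` keeps the core of compound 2 and changes only the acyl group: a group of 4 heavy atoms (4 carbon; one three-membered non-aromatic ring of carbon only) in place of a group of 4 heavy atoms (4 carbon; one four-membered non-aromatic ring of carbon only), on a carbonyl carbon. Going by the values given here, no measured pair reproduces this change, so the step can only be judged from the neighbouring acyl groups of compound 2 and compound 3, which differ modestly. The expectation for compound 4 is a step from compound 2 of a 1.6-fold higher number from compound 2 to compound 4 (0.19 log units; within the scatter), no larger than the usual scatter and of uncertain direction. Compound 4 is estimated at 25 nM, within 8 nM to 80 nM.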

Compound 4, inhibition constant: 22 nM
For compound 4 the middle estimate is 1.1-fold (0.06 log units) above the measured one, within the range that was stated.
By their numbers in this assay, from the lowest: compounds 2 and 4 (each within the scatter of the next); then compound 3; then compound 1.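

In this assay, replacing cyclobutyl on the carbonyl carbon with the group of one three-membered non-aromatic ring of carbon only gives a 1.4-fold higher number from compound 2 to compound 4 (0.14 log units; within the scatter). At this position and with the shared core, the two ring sizes, at the same count of heavy atoms, cannot be told apart. Nothing on hand bears on why the two groups read alike. Open, going by these compounds, is what the two defined stereocentres of compound 4 contribute. Also open, on these data alone, is how an acyl group carrying an amine or a carboxylic acid, or a longer chain, would read on the same carbonyl carbon.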